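This account rests on a few compounds, and the source may have more. Where it says the series, first, only, none or still open, it means among the compounds named here.

Measured so far in a functional assay on MDA-MB-231 cells (Homo sapiens) for antiproliferative activity, read by MTT assay, with a stated time of 72 h; a lower number here means a stronger inhibitor, a higher number a weaker inhibitor:
- compound 1 `CS(=O)(=O)Nc1ccc(NC(=O)Nc2cccc(-c3nc(-c4ccc(NC(=O)c5cccnc5)cc4Cl)no3)c2)cc1C(F)(F)F` gives 700 nM
- compound 2 `O=C(Nc1cccc(-c2nc(-c3ccc(NC(=O)c4cccnc4)cc3Cl)no2)c1)Nc1ccc(NC(=O)C2CCCC2)c(C(F)(F)F)c1` gives 300 nM
- compound 3 `O=C(Nc1cccc(-c2nc(-c3ccc(NC(=O)c4cccnc4)cc3Cl)no2)c1)Nc1ccc(NC(=O)c2cccs2)c(C(F)(F)F)c1` gives 2900 nM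

Compound 3 stands at the highest number of the three, so it is the weakest inhibitor; compound 2 is the strongest. Compound 4 `NC(=O)Nc1ccc(NC(=O)Nc2cccc(-c3nc(-c4ccc(NC(=O)c5cccnc5)cc4Cl)no3)c2)cc1C(F)(F)F` differs from compound 3 by amino in place of thiophen-2-yl on a carbonyl carbon. Two measured steps change the same carbonyl carbon: a 9.7-fold higher number from compound 2 to compound 3 (0.99 log units; beyond the scatter) and a 4.1-fold higher number from compound 1 to compound 3 (0.62 log units; beyond the scatter). Both show that the (thiophen-2-yl)carbonyl variant is the weakest of the set, so replacing that group is expected to bring the number down again, toward the range of compounds 1 and 2. The estimated step is a 3.6-fold lower number from compound 3 to compound 4 (0.56 log units; beyond the scatter), and compound 4 is expected at about 800 nM, within 250 nM to 2500 nM.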

Compound 4, half-maximal inhibitory concentration: 3400 nM
The estimate for compound 4 lay 4.3-fold (0.63 log units) below the measured number; the whole stated range lies below it.
By their numbers in this assay, from the lowest: compound 2; then compound 1; then compounds 3 and 4 (each within the scatter of the next).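

In this assay, amino in place of thiophen-2-yl on this carbonyl carbon gives a 1.2-fold higher number from compound 3 to compound 4 (0.07 log units; within the scatter), so these two very different groups read alike here. A ring alone does not decide the number: thiophen-2-yl and cyclopentyl both bring one, yet amino in place of cyclopentyl gives an 11-fold higher number from compound 2 to compound 4 (1.05 log units; beyond the scatter). Carbamoyl in place of methylsulfonyl gives a 4.9-fold higher number from compound 1 to compound 4 (0.69 log units; beyond the scatter), so the amino group does not match either of the two lower-number groups.

Nothing measured here explains these differences. As far as these compounds go, whether a cyclohexyl group or a longer alkyl chain on this carbonyl carbon would stay near compound 2 at 300 nM remains open.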